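This account rests on a few compounds, and the source may have more. Where it says the series, first, only, none or still open, it means among the compounds named here.

Measured compounds:
compound 1 `CC(=O)Oc1ccc(-n2c(-c3ccccc3)cc3c2CCCC3)cc1C(=O)O` — in a functional assay on the whole organism (strain Wistar) for inhibition, with Rattus norvegicus as the target, read by paw edema, with stated times of 30 min and 3 h, at a dose of 200 mg/kg by the oral route (on this read-out lower numbers stand for less inhibition and higher numbers for more inhibition at the one dose given (going by the name of the read-out)), compound 1 gives 50%
compound 2 `O=C(O)c1cc(-n2c(-c3ccccc3)cc3c2CCCC3)c(C(F)(F)F)cc1O` — in this assay compound 2 gives 0%
compound 3 `Cc1ccc(-c2cc3c(n2-c2ccc(O)c(C(=O)O)c2)CCCC3)cc1` — in this assay compound 3 gives 30%

The three measured compounds share a core and differ in the groups carried on the two aryl rings. Compound 3 stands second highest of the three numbers in this assay: compound 1 lies above it by a margin beyond the usual scatter, and compound 2 lies below it by a margin that is also beyond the scatter. No two of the measured compounds differ in only one place, so none of these gaps can be tied to a single structural change.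

Compound 4 `O=C(O)c1cc(-n2c(-c3ccc(Cl)c(Cl)c3)cc3c2CCCC3)ccc1O` has not yet been measured in this assay. It differs from compound 3 in one place: 3,4-dichlorophenyl in place of 4-methylphenyl on an aromatic carbon. Among the compounds with values here, nothing among the measured compounds tells how a change of this kind moves the read-out, so the expectation rests on compound 3 alone. The step of a number 5 percentage points higher from compound 3 to compound 4 (within the scatter) is expected to stay within the scatter, with no clear direction. Compound 4 is accordingly expected to give about 35% in this assay, in a range from 10% to 60%.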

Compound 4, a percentage reported as inhibition, in the whole organism at one dose (the size of the read-out at that dose, not a potency): 0%
The estimate for compound 4 lay 35 percentage points above the measured number, outside the stated range (below it).
By their numbers in this assay, from the lowest: compounds 2 and 4 (each within the scatter of the next); then compound 3; then compound 1.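

Within the data shown here, the exchange of 4-methylphenyl for 3,4-dichlorophenyl gives the first comparison in this set that can be tied to a single place: in this assay there is a number 30 percentage points lower from compound 3 to compound 4 (beyond the scatter). Among these compounds, the aromatic carbon next to the ring nitrogen is therefore a place where the choice of substituted phenyl matters to the read-out, and compound 3 keeps a response at the one dose given that compound 4 does not show. The two groups are alike in ring type, in hydrogen-bond donors and acceptors and in net charge, so those counts do not separate them, and no measurement shown bears on the reason for the loss.

As far as these compounds go, it remains open whether the methyl group of compound 3 or the chlorine atoms of compound 4 account for the gap, since a plain phenyl, a single chlorine or a methoxy group at this place cannot be compared on the core of compound 3. From the compounds shown here alone, it is also open whether the same exchange would have a similar effect on a compound carrying the acetyloxy group of compound 1.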